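A few compounds are considered here, and "the series" means these few. Any claim that something is new, unique, unknown or untested is made for them only; others in the source may bear on it.

Measured compounds:
- Compound 1 `CC(C)[C@@H](NC(=O)c1nc2ccccc2s1)C(=O)N1CCC(c2ccc(Cl)cc2)CC1` gives 18 nM in an assay on THP-1 cells for displacement of a labelled ligand from C-C chemokine receptor type 1 (Homo sapiens); on this read-out higher numbers stand for weaker inhibition and lower numbers for stronger inhibition.
- Compound 2 `CC(C)[C@@H](NC(=O)CCCc1ccccc1)C(=O)N1CCC(c2ccc(Cl)cc2)CC1` gives 95 nM in this assay.
- Compound 3 `Cc1ccc(CCC(=O)N[C@@H](C(=O)N2CCC(c3ccc(Cl)cc3)CC2)C(C)C)cc1` gives 105 nM in this assay.

Compound 3 stands at the highest number of the three, with compound 2 nearest and compound 1 furthest; the gap to compound 2 lies within the scatter, the gap to compound 1 beyond it.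

Compound 4 `CC(C)[C@@H](NC(=O)NCc1ccccc1)C(=O)N1CCC(c2ccc(Cl)cc2)CC1` is reached from compound 3 by one change: benzylamino in place of 2-(4-methylphenyl)ethyl on a carbonyl carbon. The steps known so far, a 5.3-fold higher number from compound 1 to compound 2 (0.72 log units; beyond the scatter) and a 5.8-fold higher number from compound 1 to compound 3 (0.77 log units; beyond the scatter), concern exchange of the benzothiazole for saturated aryl-bearing chains, and a 1.1-fold higher number from compound 2 to compound 3 (0.04 log units; within the scatter) shows the two such chains sit together. Among the measured compounds shown here, none of these steps concerns an amide-to-urea exchange, so there is no direct precedent for the nitrogen that enters. The two measured aryl-chain amides sit close together, and a shorter benzylamino link is expected to stay in that neighbourhood or drift somewhat weaker; the step is estimated as a 1.4-fold higher number from compound 3 to compound 4 (0.15 log units; within the scatter).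

Compound 4 is therefore estimated at 150 nM, with a range from 50 nM to 500 nM in this assay.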

Compound 4, half-maximal inhibitory concentration: 180 nM
Compound 4: middle estimate off by 1.2-fold (0.08 log units), on the low side, and the stated range covers the measured number.
By their numbers in this assay, from the lowest: compound 1; then compounds 2, 3 and 4 (each within the scatter of the next).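

In this assay the nitrogen that benzylamino brings to the carbonyl carbon, with its one hydrogen-bond donor, does not move the number outside the scatter of the aryl-chain amides: the reading is a 1.7-fold higher number from compound 3 to compound 4 (0.23 log units; within the scatter) and a 1.9-fold higher number from compound 2 to compound 4 (0.28 log units; within the scatter) for the two chains it replaces. Among the compounds shown here, the 1,3-benzothiazol-2-yl group stays apart from this new link as well, with a 10-fold higher number from compound 1 to compound 4 (1.00 log units; beyond the scatter) as the largest step in the set, and it is the only group of the four on this carbonyl carbon whose steps to all the others lie beyond the scatter. No accompanying measurement bears on this result.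

From the compounds shown here alone, it stays open whether a plain phenyl or a pyridine set directly on the carbonyl carbon would read like the 1,3-benzothiazol-2-yl group or like the chains. A longer phenethylamino chain, or a carboxylic acid on the benzylamino ring, would test how far this position tolerates change.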